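Replacing a dimethylphenyl amide with a chlorophenyl amide

The compounds below may be only part of what the source reports. "The series", "measured", "known", "first", "only" and "open" are said of these compounds alone.

Measured so far:
compound 1 `Cc1c(O)c(=O)ccn1CC(=O)N/N=C1\C(=O)N(CC(=O)Nc2ccccc2)c2ccccc21` — 29200 nM
compound 2 `Cc1cccc(NC(=O)CN2C(=O)/C(=N\NC(=O)Cn3ccc(=O)c(O)c3C)c3ccccc32)c1C` — 39200 nM

In a functional assay on A549 cells (Homo sapiens) for cytotoxicity, read by MTT assay, with a stated time of 48 h (a lower number here means that less compound is needed, a higher number that more compound is needed for the effect), compound 2 gives the highest of the two numbers, and compound 1 sits within the scatter of it, so the two cannot be ordered. Compound 3 `Cc1c(O)c(=O)ccn1CC(=O)N/N=C1\C(=O)N(CC(=O)Nc2cccc(Cl)c2)c2ccccc21` differs from compound 2 by 3-chlorophenyl in place of 2,3-dimethylphenyl on an amide-type nitrogen. Among the measured compounds shown here, the only step that bears on this position, a 1.3-fold higher number from compound 1 to compound 2 (0.13 log units; within the scatter), stayed within the scatter, so swapping groups on this amide nitrogen has so far moved little. Compound 3 is therefore expected to change by a 1.2-fold lower number from compound 2 to compound 3 (0.09 log units; within the scatter), with an estimate of 32000 nM and a range from 12000 nM to 85000 nM.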

Compound 3, half-maximal effective concentration: 28000 nM
Estimate against measurement, compound 3: 1.1-fold (0.06 log units) above; the range from low to high includes it.
By their numbers in this assay, from the lowest: compounds 3, 1 and 2 (each within the scatter of the next).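

In this assay, the step of a 1.4-fold lower number from compound 2 to compound 3 (0.15 log units; within the scatter) and the step of a 1.0-fold lower number from compound 1 to compound 3 (0.02 log units; within the scatter) both leave the number unchanged beyond the usual scatter. This holds both for chloro in place of hydrogen on an aromatic carbon and for 3-chlorophenyl in place of 2,3-dimethylphenyl, so phenyl, 2,3-dimethylphenyl and 3-chlorophenyl on this amide-type nitrogen cannot be ordered. Nothing measured here speaks to why these numbers stay together. Still open, from the compounds shown here alone, is whether a carboxylic acid, an amine or a longer chain in place of these aromatic groups would give a step beyond the scatter.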